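Trimming the Chlorobenzyl Substituent Down to Ethyl

The compounds below may be only part of what the source reports. "The series", "measured", "known", "first", "only" and "open" are said of these compounds alone.

Measured so far:
compound 1 `[N-]=[N+]=NCC(O)Cn1c(=O)n(C2OC(CO)[C@@H](O)[C@H]2O)c2nc(N)nc(O)c21`: 39 uM
compound 2 `Nc1nc(O)c2c(n1)n(C1OC(CO)[C@@H](O)[C@H]1O)c(=O)n2Cc1ccc(Cl)cc1`: 14 uM

In a functional assay (B cells) with Mus musculus as the target (a higher number here means that more compound is needed for the effect, a lower number that less compound is needed), compound 2 stands with the lowest of the two numbers; its nearest neighbour is compound 1, reached by a 2.8-fold lower number from compound 1 to compound 2 (0.44 log units; beyond the scatter). Compound 3 `CCn1c(=O)n(C2OC(CO)[C@@H](O)[C@H]2O)c2nc(N)nc(O)c21` differs from compound 2 by methyl in place of 4-chlorophenyl on a saturated chain carbon bound to an aromatic nitrogen. For the measured compounds named here, only that one step bears on this change, and it shows the 4-chlorophenyl group arriving together with a modest fall in the number. With that group now leaving, the expected step is a rise, estimated as a 2.9-fold higher number from compound 2 to compound 3 (0.46 log units; beyond the scatter). Compound 3 is therefore expected to give about 40 uM in this assay, within a range of 15 uM to 110 uM.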

Compound 3, concentration for half-maximal effect: 15 uM
Beside the measured number, compound 3's estimate is 2.7-fold (0.43 log units) above it; the range from low to high includes it.
By their numbers in this assay, from the lowest: compounds 2 and 3 (each within the scatter of the next); then compound 1.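

In this assay a step of a 1.1-fold higher number from compound 2 to compound 3 (0.03 log units; within the scatter) means that the whole 4-chlorophenyl ring can leave this position, with ethyl left in place of 4-chlorobenzyl, and no change can be read. A step of a 2.6-fold lower number from compound 1 to compound 3 (0.41 log units; beyond the scatter) then shows that the lower number seen earlier with 4-chlorobenzyl does not depend on that ring, since ethyl also stands apart from the chain bearing 2-azido-1-hydroxyethyl. On these data alone, whether a longer chain such as propyl, or a chain ending in an amine or a carboxylic acid, would keep this number remains open. Nothing available explains why so small a group matches the larger one.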